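Dichloroacetanilides: meta substituent swap, trifluoromethoxy to trifluoromethylsulfanyl

The source may hold more compounds than are shown below. What is called first, only, known or untested is meant among the compounds shown, and "the series" means these compounds.

Compound 1 `O=C(Nc1cccc(Br)c1)C(Cl)Cl` and compound 2 `O=C(Nc1cccc(OC(F)(F)F)c1)C(Cl)Cl` share the dichloroacetamide core and differ only in the group on the aromatic ring. In a functional assay on Bel-7402 cells (Homo sapiens) for antiproliferative activity, read by MTT assay, with a stated time of 72 h (on this read-out higher numbers stand for weaker inhibition and lower numbers for stronger inhibition), compound 1 gives 7720 nM, and compound 2 gives 10300 nM. The step of a 1.3-fold higher number from compound 1 to compound 2 (0.13 log units; within the scatter) shows that exchanging bromo for trifluoromethoxy leaves the read-out essentially unchanged. For the measured compounds named here, compound 2 therefore carries the higher of the two numbers seen so far, with compound 1 as its only neighbour, and the gap between them is not one to read anything into.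

Compound 3 `O=C(Nc1cccc(SC(F)(F)F)c1)C(Cl)Cl` continues from compound 2 with the change ((trifluoromethyl)sulfanyl in place of trifluoromethoxy on an aromatic carbon). Going by the values given here, the only step that bears on it is the one from compound 1 to compound 2, a swap of one small meta group for another of the same size, which stayed within the scatter. Among the compounds with values here, nothing among the measured compounds points to a movement beyond the scatter here either; the expected step is a 1.1-fold lower number from compound 2 to compound 3 (0.04 log units; within the scatter).

For compound 3 in this assay a value of 9500 nM is estimated, with a range from 4000 nM to 22000 nM.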

Compound 3, half-maximal inhibitory concentration: 6540 nM
For compound 3 the middle estimate is 1.5-fold (0.16 log units) above the measured one; measured number inside the range.
By their numbers in this assay, from the lowest: compounds 3, 1 and 2 (each within the scatter of the next).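

In this assay, for the compounds shown here, the exchange of trifluoromethoxy for (trifluoromethyl)sulfanyl gives a 1.6-fold lower number from compound 2 to compound 3 (0.20 log units; within the scatter) and the exchange of bromo for the same group gives a 1.2-fold lower number from compound 1 to compound 3 (0.07 log units; within the scatter) so no pair among the three groups at this aromatic carbon now separates beyond the scatter. Going by these compounds alone, the earlier pair showed only one exchange of bromo for trifluoromethoxy, whereas this step keeps the heavy-atom count of the group and replaces one oxygen with one sulfur, and that exchange also leaves the read-out within the scatter. No measurement is available that would explain why these numbers stay so close.

The compounds shown leave open whether any group at this place can move the number beyond the scatter, since an amine, a carboxylic acid and a longer alkyl chain all lie outside the set. They also leave open whether bromo, trifluoromethoxy and (trifluoromethyl)sulfanyl would remain interchangeable at another carbon of the ring, or on a core with a changed dichloroacetamide part.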